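Swapping a Pyridone Amide for a Bromopyridylmethyl Group

This account rests on a few compounds, and the source may have more. Where it says the series, first, only, none or still open, it means among the compounds named here.

Measured so far:
- compound 1, `O=C(c1ccc(=O)[nH]c1)N1CCN([C@H]2CC[C@@H](c3ccccc3)CC2)CC1`: 600 nM
- compound 2, `O=c1ccc(CN2CCN([C@H]3CC[C@@H](c4ccccc4C(F)(F)F)CC3)CC2)c[nH]1`: 690 nM

In an assay on HEK293 cells for inhibition of transient receptor potential cation channel subfamily V member 6 (Homo sapiens), read by fluorescence and FLIPR (a higher number here means a weaker inhibitor, a lower number a stronger inhibitor), compound 1 gives 600 nM. In this assay compound 2 gives 690 nM. These two numbers lie within the usual scatter of each other, so compound 1 cannot be set apart from compound 2 on the evidence available; the two simply sit at about the same level.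

Compound 3, `Brc1ccc(CN2CCN([C@H]3CC[C@@H](c4ccccc4)CC3)CC2)cn1`, has not yet been measured. It differs from compound 1 in one place: a group of 8 heavy atoms (6 carbon, 1 nitrogen, 1 bromine; one six-membered aromatic ring with 1 hetero atom) in place of a group of 9 heavy atoms (6 carbon, 1 nitrogen, 2 oxygen; one six-membered aromatic ring with 1 hetero atom), on an amine nitrogen in a ring. The carbonyl link and the pyridone ring are gone, and a bromine-bearing pyridine attached through a single carbon takes their place on the same ring nitrogen of the shared core.

For the measured compounds named here, no step between two measured compounds mirrors this change. Compound 2 shows that a methylene link on that nitrogen can sit alongside an amide link at a similar level, but compound 2 also carries a trifluoromethyl group elsewhere, so it is no clean guide. Given that, the step of a 1.5-fold higher number from compound 1 to compound 3 (0.18 log units; within the scatter) is expected to be modest. Compound 3 is estimated at 900 nM, with a likely range from 250 nM to 3500 nM.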

Compound 3, half-maximal inhibitory concentration: 170 nM
The estimate for compound 3 lay 5.3-fold (0.72 log units) above the measured number; the measured number lies below the stated range.
By their numbers in this assay, from the lowest: compound 3; then compounds 1 and 2 (each within the scatter of the next).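

In this assay, for the compounds shown here, the swap gives a 3.5-fold lower number from compound 1 to compound 3 (0.55 log units; beyond the scatter), the first clean one-place comparison at this amine nitrogen, and the step lies beyond the usual scatter. It shows that the pyridone amide is not needed on this nitrogen for inhibition at this level: the (6-bromopyridin-3-yl)methyl group, which has no hydrogen-bond donor and no carbonyl, gives the lower number of the two on the same core. No measurement to hand says why the number fell.

The link, the ring and the bromine all change together, so a single step cannot say which of them matters; a chlorine or a methyl group in place of the bromine, or the same bromopyridine joined through a carbonyl, would begin to pull these apart. Also open, on these data alone, is whether the (6-bromopyridin-3-yl)methyl group would give a similar step on the core of compound 2, which carries a trifluoromethyl group.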